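Second chloro on the benzyl ether

A few compounds are considered here, and "the series" means these few. Any claim that something is new, unique, unknown or untested is made for them only; others in the source may bear on it.

Compound 1 `COc1ccc(CCCN2CCC(CO)CC2)cc1`: > 20000 nM (a limit)
Compound 2 `COc1ccc(CCCN2CCC(COCc3ccc(Cl)cc3)CC2)cc1`: 500 nM
Compound 3 `COc1ccc(CCCN2CCC(COCc3ccc(Cl)c(Cl)c3)CC2)cc1`: not yet measured

For the measured compounds named here, in a functional assay on cells (T-cell line, Homo sapiens) for inhibition (on this read-out higher numbers stand for weaker inhibition and lower numbers for stronger inhibition), compound 2 gives 500 nM and holds the only actual number so far. Compound 1 reads > 20000 nM and that value is a limit.

Compound 3 differs from compound 2 by chloro in place of hydrogen on an aromatic carbon, ortho to a chloro group and meta to a large group, 4-chlorobenzyl to 3,4-dichlorobenzyl (chloro in place of hydrogen on an aromatic carbon).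

Going by the values given here, only one measured step bears on this: an at least 40-fold lower number from compound 1 to compound 2 (1.60 log units; beyond the scatter), which is large, open-ended through the limit of > 20000 nM in this assay, at which 1 of the 2 values shown sits, and concerns the whole 4-chlorobenzyl group. Among the compounds with values here, no measured step varies substitution on that ring, so only a modest move in this assay towards a lower number is expected, possibly within the scatter. The estimated change is a 1.7-fold lower number from compound 2 to compound 3 (0.22 log units; within the scatter) for this pair. Compound 3 is expected at 300 nM, with an estimated range of 80 nM to 1000 nM for the measurement.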

Compound 3, half-maximal inhibitory concentration: 200 nM
Estimate against measurement, compound 3: 1.5-fold (0.18 log units) above, and the stated range covers the measured number.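

In this assay, chloro at this place, ortho to a chloro group and meta to a large group, gives a 2.5-fold lower number from compound 2 to compound 3 (0.40 log units; beyond the scatter). The earlier step concerned the whole 4-chlorobenzyl group, whereas this one shows, between two actual numbers, that substitution on the ring itself moves the read-out, though only modestly. Compound 1 remains a limit, so an at least 100-fold lower number from compound 1 to compound 3 (2.00 log units; beyond the scatter) is open-ended: the limit of > 20000 nM in this assay, at which 1 of the 3 values shown sits.

Still open, from the compounds shown here alone, is whether fluoro, methoxy or a nitrile at the same place would match the second chloro, and whether the first chloro is still needed once the second is present. Going by these compounds, the benzyl ether link is also untested, so it remains unknown whether an amide could stand in its place.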